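Aryl replacement on the double-bonded nitrogen: compound 3

A few compounds are considered here, and "the series" means these few. Any claim that something is new, unique, unknown or untested is made for them only; others in the source may bear on it.

Measured so far:
compound 1 `COc1ccccc1/N=N/C(=N/NC(=O)c1cc(O)c(O)c(O)c1)c1ccccc1`: 52.7%
compound 2 `COc1ccc(/N=N/C(=N/NC(=O)c2cc(O)c(O)c(O)c2)c2ccccc2)cc1`: 15%

In an ADME assay on RAW264.7 cells (Mus musculus) for inhibition, read by MTT assay, with a stated time of 72 h, tested at 100 uM (a higher number here means more inhibition of growth at the concentration tested, a lower number less inhibition of growth), compound 1 gives 52.7% and stands highest of the two numbers. Compound 2 gives 15%. Within the data shown here, the only measured step is a number 37.7 percentage points lower from compound 1 to compound 2 (beyond the scatter), a large downward move from changing the aryl group on the double-bonded nitrogen.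

Compound 3 `O=C(N/N=C(/N=N/c1ccc(Cl)cc1Cl)c1ccccc1)c1cc(O)c(O)c(O)c1` differs from compound 1 by 2,4-dichlorophenyl in place of 2-methoxyphenyl on a double-bonded nitrogen. The step from compound 1 to compound 2 bears on it only loosely, since it alters the same group at the same place but to a different group; it shows the number can fall sharply there. A downward step is therefore expected, of uncertain size, as a number 20.7 percentage points lower from compound 1 to compound 3 (beyond the scatter). Compound 3 is estimated at 32%, within 10% to 58%.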

Compound 3, percent growth inhibition at one concentration: 21.5%
Compound 3: middle estimate off by 10.5 percentage points, on the high side, and the stated range covers the measured number.
By their numbers in this assay, from the lowest: compounds 2 and 3 (each within the scatter of the next); then compound 1.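

With a number 31.2 percentage points lower from compound 1 to compound 3 (beyond the scatter) in this assay, a second group in place of 2-methoxyphenyl on the double-bonded nitrogen also lowers growth inhibition, so the fall is not confined to the 4-methoxyphenyl change. Between the two replacements there is a number 6.5 percentage points higher from compound 2 to compound 3 (within the scatter), leaving compound 1 alone apart from compound 2 and compound 3. Nothing available here accounts for this difference. Still open, from the compounds shown here alone, is how a plain phenyl, or a phenyl carrying an amine or a carboxylic acid, would read at this place.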